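Trimethoxyphenyl for methoxyphenyl on a second chalcone-linked core

This account rests on a few compounds, and the source may have more. Where it says the series, first, only, none or still open, it means among the compounds named here.

Measured compounds:
compound 1 `COc1ccccc1/C=C/C(=O)c1ccc(OCCn2cc(CN3C(=O)/C=C/C(C)(C)C/C=C(\C)CC/C=C/3C)nn2)cc1O`: 1.71 ug/mL
compound 2 `COc1cc(/C=C/C(=O)c2ccc(OCCn3cc(CN4C(=O)/C=C/C(C)(C)C/C=C(\C)CC/C=C/4C)nn3)cc2O)cc(OC)c1OC`: 1.44 ug/mL
compound 3 `COc1ccccc1/C=C/C(=O)c1ccc(OCCCN2C(=O)/C=C/C(C)(C)C/C=C(\C)CC/C=C/2C)cc1`: 1.44 ug/mL

In a functional assay on HepG2 cells (Homo sapiens) for antiproliferative activity (a lower number here means a stronger inhibitor, a higher number a weaker inhibitor), compound 1 gives 1.71 ug/mL and compound 2 gives 1.44 ug/mL. The two share a core and differ in one place, (3,4,5-trimethoxyphenyl in place of 2-methoxyphenyl on a double-bonded chain carbon bound to a double-bonded chain carbon); the step is a 1.2-fold lower number from compound 1 to compound 2 (0.07 log units; within the scatter), so the two numbers cannot be told apart. Compound 3 is built on a different core, and the difference between the two cores is not broken down here; in this assay compound 3 gives 1.44 ug/mL, which stands level with compound 2 at the digits shown and is not separated from compound 1 either.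

Compound 4 `COc1cc(/C=C/C(=O)c2ccc(OCCCN3C(=O)/C=C/C(C)(C)C/C=C(\C)CC/C=C/3C)cc2)cc(OC)c1OC` has not yet been measured. It differs from compound 3 by 3,4,5-trimethoxyphenyl in place of 2-methoxyphenyl on a double-bonded chain carbon bound to a double-bonded chain carbon, the same structural change that turns compound 1 into compound 2, which occurs twice among these compounds. Because that step was a 1.2-fold lower number from compound 1 to compound 2 (0.07 log units; within the scatter), the step from compound 3 to compound 4 is expected to be of similar, negligible size, a 1.1-fold lower number from compound 3 to compound 4 (0.04 log units; within the scatter). Compound 4 is therefore estimated at 1.3 ug/mL, between 0.7 ug/mL and 2.5 ug/mL.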

Compound 4, half-maximal inhibitory concentration: 0.99 ug/mL
The estimate for compound 4 lay 1.3-fold (0.12 log units) above the measured number, and the stated range covers the measured number.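

In this assay, placing 3,4,5-trimethoxyphenyl in place of 2-methoxyphenyl gives a 1.5-fold lower number from compound 3 to compound 4 (0.16 log units; within the scatter), so on this second core the step again cannot be separated from the scatter. Set beside the earlier step, the new one does not differ from it by more than such steps can: the same change on two cores in this assay, a 1.2-fold lower number (0.07 log units; within the scatter) from compound 1 to compound 2 and a 1.5-fold lower number (0.16 log units; within the scatter) from compound 3 to compound 4, 1.2-fold (0.09 log units) apart, within the scatter of two such steps. This shows that the change behaves alike on the two cores as far as this pair of steps can tell, but it does not show that the change improves activity on either core, nor does it show that the steps would stay alike on a third core.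

The compounds shown leave open what an unsubstituted phenyl, or an aromatic ring carrying an amine or a carboxylic acid, would do on the same double-bonded chain carbon. They also leave open how a longer chain to the large ring would read in this assay, and which of the several differences between the two cores matters, if any does.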